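The compounds below may be only part of what the source reports. "The series", "measured", "known", "first", "only" and "open" are said of these compounds alone.

Working notes on the series. Compound 1 `CCC(=O)c1ccc2c(c1)C(n1ccccc1=O)=CC(C)(C)O2` gives 5.85 in a functional assay (trachea) with Rattus norvegicus as the target; on this read-out lower numbers stand for lower potency and higher numbers for higher potency (the scale is a negative logarithm); compound 2 `CC(=O)Oc1ccc2c(c1)C(n1ccccc1=O)=CC(C)(C)O2` gives 4.97, the lowest of the two numbers, with the drop a number 0.88 log units lower from compound 1 to compound 2 (beyond the scatter) between them. Compound 3 `CC1(C)C=C(n2ccccc2=O)c2cc(Br)ccc2O1` carries bromo in place of acetoxy on an aromatic carbon. No measured step involves bromo; the only step shown removed propanoyl, so the weight of the acetoxy group itself is unknown. Compound 3 is therefore expected to land between the two measured numbers, with the step of a number 0.43 log units higher from compound 2 to compound 3 (beyond the scatter) as an estimate only. For compound 3 the estimate is 5.4, in the range 4.7 to 6.1.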

Compound 3, logarithm of the reciprocal of the active concentration, log(1/C): 7.53
For compound 3 the middle estimate is 2.13 log units below the measured one, and the stated range ends below it.
By their numbers in this assay, from the lowest: compound 2; then compound 1; then compound 3.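

Replacing the earlier groups with bromo on this aromatic carbon gives a number 2.56 log units higher from compound 2 to compound 3 (beyond the scatter) and a number 1.68 log units higher from compound 1 to compound 3 (beyond the scatter) in the same series. The acetoxy and propanoyl pair showed only a modest spread, whereas this result shows a much wider span at this position, with the single-atom bromo group highest of the three. No available evidence accounts for the size of this gain and the step stands as an observation only.

From the compounds shown here alone, whether chloro, nitrile or trifluoromethyl would match bromo here remains open. Also open, going by these compounds, is how the unsubstituted carbon or an amine would compare.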